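Replacing a Sulfur-Linked Heteroaryl with an Oxygen-Linked One

The source may report more compounds than this note shows. Statements on the series, on what has been measured and on what is new or still open speak of the compounds shown alone.

Measured so far in a functional assay on Jurkat cells (Homo sapiens) for inhibition; a lower number here means a stronger inhibitor, a higher number a weaker inhibitor:
- Compound 1, `CC(C)[C@H](NC(=O)COc1cccc2ccccc12)C(=O)N[C@@H](CC(=O)O)C(=O)CSc1nc(-c2ccccc2)cs1`, gives > 200000 nM, which is a limit of the assay rather than a number.
- Compound 2, `CC(C)[C@H](NC(=O)COc1cccc2ccccc12)C(=O)N[C@@H](CC(=O)O)C(=O)CSc1nc(-c2ccccc2)no1`, gives 102000 nM.
- Compound 3, `CC(C)[C@H](NC(=O)COc1cccc2ccccc12)C(=O)N[C@@H](CC(=O)O)C(=O)CSc1nc2ccccc2s1`, gives > 200000 nM, again a limit of the assay and not a number.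

Compound 3 therefore stands at the limit of > 200000 nM in this assay, at which 2 of the 3 values shown sit. The three measured steps all exchange the heteroaryl group on the sulfur: an at least 1.9-fold lower number from compound 1 to compound 2 (0.29 log units; that floor lies within the scatter), an at least 1.9-fold higher number from compound 2 to compound 3 (0.29 log units; that floor lies within the scatter), and a step that the two limits leave unreadable from compound 1 to compound 3. None of them reaches beyond the scatter, so across this small set the exchange of the ring on the sulfur has produced no readable shift.

Compound 4, `CC(C)[C@H](NC(=O)COc1cccc2ccccc12)C(=O)N[C@@H](CC(=O)O)C(=O)COc1cc2ccccc2cn1`, changes something else: (isoquinolin-3-yl)oxy in place of (1,3-benzothiazol-2-yl)sulfanyl on a saturated chain carbon bound to a carbonyl carbon. Among the compounds with values here, no measured step bears directly on replacing the sulfur link by an oxygen link together with the ring. Since every measured compound sharing this core stays at or near the limit, compound 4 is expected to do the same, with a step of a number no higher from compound 3 to compound 4 (the limit leaves the size open) that is expected to lie within the scatter. The value for compound 4 is estimated at 200000 nM, between 60000 nM and 400000 nM, and it may well be reported only as a limit.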

Compound 4, half-maximal inhibitory concentration: > 200000 nM
Compound 4: only a limit was reported; the forecaster's own chance of this, stated with the estimate: 60%; the middle value lies on the limit itself.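

In this assay compound 4 gives > 200000 nM, which is a limit of the assay and not a number. Within the data shown here, the only step that can be read is an at least 1.9-fold higher number from compound 2 to compound 4 (0.29 log units; that floor lies within the scatter); the steps from compound 1 and compound 3 to compound 4 cannot be read. The new result shows that an oxygen-linked group on this saturated chain carbon bound to a carbonyl carbon, here (isoquinolin-3-yl)oxy, also brings no readable gain, and the limit now holds most of the set: the limit of > 200000 nM in this assay, at which 3 of the 4 values shown sit.

Going by these compounds, the ring and the linking atom changed together in compound 4, so their separate contributions remain unknown, and a (1,3-benzothiazol-2-yl)oxy group would tell them apart. On these data alone, whether a quite different group at this place, such as an amine, would give a number well clear of the limit also remains open.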